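The compounds below may be only part of what the source reports. "The series", "measured", "known", "first", "only" and "open" are said of these compounds alone.

Compound 1 `OC[C@H]1O[C@@H](n2cnc3c(NCc4cccc(F)c4)ncnc32)[C@H](O)[C@@H]1O` carries a 3-fluorophenyl group on a saturated chain carbon bound to a nitrogen on an aromatic ring. In a functional assay on G-361 cells (Homo sapiens) for antiproliferative activity, with a stated time of 72 h (on this read-out lower numbers stand for stronger inhibition and higher numbers for weaker inhibition), compound 1 gives no number, only a limit of > 166000 nM. Its close relative compound 2 `OC[C@H]1O[C@@H](n2cnc3c(NCc4ccccc4Br)ncnc32)[C@H](O)[C@@H]1O` in this assay likewise gives only a limit of > 166000 nM. The step that the two limits leave unreadable from compound 1 to compound 2 therefore cannot be read, as the limit of > 166000 nM in this assay, at which 2 of the 2 values shown sit, shows. Compound 3 `OC[C@H]1O[C@@H](n2cnc3c(NCc4ccc(F)cc4F)ncnc32)[C@H](O)[C@@H]1O` differs from compound 1 by 2,4-difluorophenyl in place of 3-fluorophenyl on a saturated chain carbon bound to a nitrogen on an aromatic ring. No readable step bears on this change. The expected step is a step that the limit leaves unreadable from compound 1 to compound 3. Compound 3 is estimated at 200000 nM, within 100000 nM to 500000 nM, most likely again only a limit.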

Compound 3, half-maximal inhibitory concentration: > 166000 nM
Compound 3: a limit, no number; the forecaster's own chance of this, stated with the estimate: 85%; the middle value lies beyond the limit too.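

Among the compounds shown here, compound 3 also gives only a limit, so no step among compound 1, compound 2 and compound 3 can be read in this assay here: the limit of > 166000 nM in this assay, at which 3 of the 3 values shown sit. From the compounds shown here alone, whether the 3-fluorophenyl, 2-bromophenyl or 2,4-difluorophenyl group makes any difference on the shared core stays open.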